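The compounds below may be only part of what the source reports. "The series", "measured", "known", "first", "only" and "open" are said of these compounds alone.

Compound 1, `CCOc1ccc(C(=O)/C=C/c2ccc(F)cc2)cc1`: 53 nM
Compound 2, `O=C(/C=C/c1cccc(F)c1)c1ccc(-n2ccnc2)cc1`: > 10000 nM
Compound 3, `COc1cccc(/C=C/C(=O)c2ccc(O/N=C(\C)c3cccs3)cc2)c1`: < 300 nM

All three were tested in an assay on isolated protein for inhibition of Amine oxidase [flavin-containing] B (Homo sapiens); on this read-out lower numbers stand for stronger inhibition and higher numbers for weaker inhibition. Compound 1 gives 53 nM. For compound 3 the read-out is a limit of the assay, < 300 nM, and not a number. For compound 2 also only a limit is known, > 10000 nM, so its inhibition is not quantified. Compound 2 therefore stands at the limit of > 10000 nM in this assay, at which 1 of the 3 values shown sits, at the high-number end of the values shown, while the other value that is a limit sits at the limit of < 300 nM in this assay, at which 1 of the 3 values shown sits. Compound 4, `O=C(/C=C/c1ccc(Br)cc1)c1ccc(-n2ccnc2)cc1`, is compound 2 with one change: 4-bromophenyl in place of 3-fluorophenyl on a double-bonded chain carbon bound to a double-bonded chain carbon. Going by the values given here, no pair among the measured compounds differs by this same change, so there is no measured step to lean on, and the size of the move cannot be read from the data. Compound 4 shares the rest of its structure with compound 2, which gave only a limit, so the expectation for compound 4 is a modest move toward stronger inhibition at best, and a fair chance that the assay again reports only a limit. The expected step from compound 2 to compound 4 is an at least 1.6-fold lower number from compound 2 to compound 4 (0.22 log units; that floor lies within the scatter). Compound 4 is estimated at 6000 nM, with a range from 1000 nM to 40000 nM.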

Compound 4, half-maximal inhibitory concentration: 320 nM
The estimate for compound 4 lay 19-fold (1.27 log units) above the measured number, and the stated range ends above it.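

Replacing 3-fluorophenyl with 4-bromophenyl on a double-bonded chain carbon bound to a double-bonded chain carbon gives an at least 31-fold lower number from compound 2 to compound 4 (1.49 log units; beyond the scatter) in this assay. Going by these compounds alone, the shared core therefore does not by itself rule out a measurable read-out, and this position alone can take the read-out from a limit to a number, something the earlier compounds could not show, as no two of them differed in one place. The size of the step is only a floor, because the value for compound 2 is a limit and not a number: the limit of > 10000 nM in this assay, at which 1 of the 4 values shown sits.

The change alters both the halogen and its place on the phenyl ring, so the compounds shown cannot separate the two, and 3-bromophenyl or 4-fluorophenyl at this position would be needed to tell them apart. Going by these compounds, it also remains open whether the gain is particular to bromine or extends to other groups on the ring, such as 4-chlorophenyl or 4-aminophenyl, and whether the same change would carry over to the cores of compound 1 and compound 3.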